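This account rests on a few compounds, and the source may have more. Where it says the series, first, only, none or still open, it means among the compounds named here.

Measured so far:
- compound 1 `Cc1ccccc1C1CC(c2ccc(OCc3ccccc3)cc2)=NN1c1ccc(S(N)(=O)=O)cc1`: 100000 nM
- compound 2 `NS(=O)(=O)c1ccc(N2N=C(c3ccc(OCc4ccccc4)cc3)CC2c2ccccc2)cc1`: > 100000 nM
- compound 3 `NS(=O)(=O)c1ccc(N2N=C(c3ccc(OCc4ccccc4)cc3)CC2c2ccc(F)cc2)cc1`: 90000 nM

In an ADME assay on Vero 76 cells (Chlorocebus sabaeus) for cytotoxicity, read by MTT assay, with a stated time of 96 h (on this read-out lower numbers stand for higher toxicity in this test and higher numbers for lower toxicity in this test), compound 1 gives 100000 nM. For compound 2 the result is a limit of the test, > 100000 nM, not a number. Compound 3 gives 90000 nM, the lowest of the two numbers, with compound 1 nearest at a 1.1-fold lower number from compound 1 to compound 3 (0.05 log units; within the scatter). Compound 4 `NS(=O)(=O)c1ccc(N2N=C(c3ccc(OCc4ccccc4)cc3)CC2c2ccccc2Cl)cc1` differs from compound 3 in one place: 2-chlorophenyl in place of 4-fluorophenyl on a saturated ring carbon. Among the measured compounds shown here, two measured steps touch this position: a 1.1-fold lower number from compound 1 to compound 3 (0.05 log units; within the scatter), and an at least 1.1-fold lower number from compound 2 to compound 3 (0.04 log units; that floor lies within the scatter). Neither moved beyond the scatter, so no shift beyond the scatter is expected in this assay. Compound 4 is therefore estimated at 100000 nM, with a range from 45000 nM to 200000 nM. That estimate means an expected step of a 1.1-fold higher number from compound 3 to compound 4 (0.05 log units; within the scatter).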

Compound 4, half-maximal cytotoxic concentration: 92000 nM
Compound 4: the middle estimate sits 1.1-fold (0.04 log units) above what was measured, and the stated range covers the measured number.
By their numbers in this assay, from the lowest: compounds 3, 4 and 1 (each within the scatter of the next).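

In this assay, the 2-chlorophenyl group at this saturated ring carbon gives a number within the scatter of both the 4-fluorophenyl group (a 1.0-fold higher number from compound 3 to compound 4 (0.01 log units; within the scatter)) and the 2-methylphenyl group (a 1.1-fold lower number from compound 1 to compound 4 (0.04 log units; within the scatter)). So a chloro group now joins fluoro and methyl on this phenyl ring with no shift beyond the scatter. Chloro in place of hydrogen gives only a floor, which also lies within the scatter (an at least 1.0-fold lower number from compound 2 to compound 4 (0.03 log units; that floor lies within the scatter)), and compound 2 stands at a limit of the test: the limit of > 100000 nM in this assay, at which 1 of the 4 values shown sits.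

The compounds shown leave open whether an amine or a carboxylic acid on this phenyl ring, or a longer chain in its place, would move the number beyond the scatter.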